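A trifluoromethylphenyl swap on a sulfonyl sulfur

This account rests on a few compounds, and the source may have more. Where it says the series, first, only, none or still open, it means among the compounds named here.

compound 1 `Cc1ccc(S(=O)(=O)NC(=N)N2CCN(c3cc4c(cc3F)c(=O)c(C(=O)O)cn4C3CC3)CC2)cc1`: 32 nM
compound 2 `N=C(NS(=O)(=O)c1cccc(Cl)c1)N1CCN(c2cc3c(cc2F)c(=O)c(C(=O)O)cn3C2CC2)CC1`: 32 nM
compound 3 `N=C(NS(=O)(=O)c1ccc(C(F)(F)F)cc1)N1CCN(c2cc3c(cc2F)c(=O)c(C(=O)O)cn3C2CC2)CC1`: 32 nM

All three values come from a functional assay on HeLa cells (Homo sapiens) for antiproliferative activity, read by MTT assay, with a stated time of 72 h; on this read-out higher numbers stand for weaker inhibition and lower numbers for stronger inhibition. Compound 1 and compound 2 stand level with compound 3, at 32 nM.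

The unmeasured compound 4 `N=C(NS(=O)(=O)c1ccccc1C(F)(F)F)N1CCN(c2cc3c(cc2F)c(=O)c(C(=O)O)cn3C2CC2)CC1` has the same atoms as compound 3, joined differently: 2-(trifluoromethyl)phenyl in place of 4-(trifluoromethyl)phenyl on a sulfonyl sulfur.

Three measured steps change the group on that aromatic ring or sulfur, and they show no change at the digits printed from compound 1 to compound 2 (within the scatter), no change at the digits printed from compound 1 to compound 3 (within the scatter) and no change at the digits printed from compound 2 to compound 3 (within the scatter). None of these compounds carries the 2-(trifluoromethyl)phenyl group, so the new arrangement is untested and some uncertainty remains. Even so, with all three steps this small, no change beyond the scatter is expected in this assay, and neither direction is favoured. The estimated step is a 1.1-fold higher number from compound 3 to compound 4 (0.04 log units; within the scatter). For compound 4 the estimated value is 35 nM, with an expected range of 14 nM to 90 nM.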

Compound 4, half-maximal inhibitory concentration: 32 nM
Beside the measured number, compound 4's estimate is 1.1-fold (0.04 log units) above it; low and high end bracket the measured number.
By their numbers in this assay, from the lowest: compounds 1, 2, 3 and 4 (each within the scatter of the next).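

Moving the trifluoromethyl group, so that 2-(trifluoromethyl)phenyl replaces 4-(trifluoromethyl)phenyl on the sulfonyl sulfur, gives no change at the digits printed from compound 3 to compound 4 (within the scatter) in this assay. The new group also matches the two other rings, with no change at the digits printed from compound 2 to compound 4 (within the scatter) and no change at the digits printed from compound 1 to compound 4 (within the scatter). Going by these compounds alone, the earlier compounds showed only that different groups on this ring gave the same number, and compound 4 adds that rearranging the same atoms does too, though nothing available explains this flat result.

Going by these compounds, all four compounds carry a substituted phenyl ring on the sulfonyl sulfur, so it remains open whether an amine or a carboxylic acid on that ring would shift the number. On these data alone, it is equally open whether a plain butyl chain in place of the ring would do so.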